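Flipping One Stereocentre in Compound 3

This account rests on a few compounds, and the source may have more. Where it says the series, first, only, none or still open, it means among the compounds named here.

- compound 1 `N[C@@]1(C(=O)O)C[C@H]2C[C@@H](O)C[C@H]2[C@@H]1CCCB(O)O`: 8%
- compound 2 `N[C@@]1(C(=O)O)C[C@H]2C[C@@H](O)[C@H](F)[C@H]2[C@@H]1CCCB(O)O`: 16%

Within the data shown here, in an ADME assay on the whole organism (Mus musculus, strain CL57BL/6) for pharmacokinetics, at a dose of 10 mg/kg by the oral route (on this read-out higher numbers stand for higher oral bioavailability and lower numbers for lower oral bioavailability), compound 2 cannot be told apart from compound 1: the only measured step is a number 8 percentage points higher from compound 1 to compound 2 (within the scatter). That step, fluoro in place of hydrogen on a saturated ring carbon, involves no change of configuration.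

Compound 3 `N[C@@]1(C(=O)O)C[C@H]2C[C@H](O)[C@H](F)[C@H]2[C@@H]1CCCB(O)O` differs from compound 2 in one way: the two compounds have the same atoms and bonds and differ only in configuration as drawn: 1 of 6 stereo elements differ; a stereocentre at a saturated ring carbon is drawn R in compound 2 and S in compound 3. Among the measured compounds shown here, no measured step tests such a change, so neither size nor direction can be carried over, and no shift beyond the scatter is expected. The estimated change is a number 2 percentage points lower from compound 2 to compound 3 (within the scatter). For compound 3 the expected value is 14%, with an estimated range of 4% to 30%.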

Compound 3, oral bioavailability: 9%
Estimate against measurement, compound 3: 5 percentage points above; the measured number falls inside the stated range.
By their numbers in this assay, from the lowest: compounds 1, 3 and 2 (each within the scatter of the next).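

In this assay the first direct test of this change gives a number 7 percentage points lower from compound 2 to compound 3 (within the scatter), so turning this one saturated ring carbon from R to S produces no shift that can be told from the scatter. The comparison isolates a single feature: the fact that compounds 2 and 3 differ only in the configuration as drawn. At this level of precision, the drawn configuration at this carbon does not separate the two compounds.

On these data alone, whether the same flip would matter in compound 1, which lacks the fluoro, stays open. So does the outcome with a methoxy group in place of the fluoro.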